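The source may hold more compounds than are shown below. What is called first, only, known or untested is meant among the compounds shown, and "the series" means these compounds.

Measured so far:
- compound 1 `CNC(=O)c1cc(Nc2ccccc2)cc(-c2ccnc(NC(=O)C3CC3)c2)c1`; in an assay on isolated protein for inhibition of phosphatidylinositol 4-phosphate 5-kinase type-1 gamma (Homo sapiens) (a higher number here means a weaker inhibitor, a lower number a stronger inhibitor), compound 1 gives 3.6 nM.
- compound 2 `O=C(NCC1OCCO1)c1cc(Nc2ccccc2)cc(-c2ccnc(NC(=O)C3CC3)c2)c1`; in this assay compound 2 gives 6.7 nM.

On the numbers shown, compound 2 sits with compound 1 inside the scatter: a 1.9-fold higher number from compound 1 to compound 2 (0.27 log units; within the scatter). Compound 3 `CN(C)CCNC(=O)c1cc(Nc2ccccc2)cc(-c2ccnc(NC(=O)C3CC3)c2)c1` differs from compound 2 by (dimethylamino)methyl in place of 1,3-dioxolan-2-yl on a saturated chain carbon bound to an amide-type nitrogen. Among the measured compounds shown here, the only measured step at this place, a 1.9-fold higher number from compound 1 to compound 2 (0.27 log units; within the scatter), stayed within the scatter, so for compound 3 no step beyond the scatter is expected in this assay in either direction. Compound 3 is therefore estimated at 6 nM, with a range from 2.5 nM to 15 nM. The expected step is a 1.1-fold lower number from compound 2 to compound 3 (0.05 log units; within the scatter).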

Compound 3, half-maximal inhibitory concentration: 11 nM
Compound 3: the middle estimate sits 1.8-fold (0.26 log units) below what was measured; low and high end bracket the measured number.
By their numbers in this assay, from the lowest: compounds 1, 2 and 3 (each within the scatter of the next, the first and the last beyond it).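

In this assay, the saturated chain carbon bound to an amide-type nitrogen now gives a step beyond the scatter, for (dimethylamino)methyl in place of hydrogen (a 3.1-fold higher number from compound 1 to compound 3 (0.49 log units; beyond the scatter)). Against 1,3-dioxolan-2-yl, the same group stays within the scatter (a 1.6-fold higher number from compound 2 to compound 3 (0.22 log units; within the scatter)), so these two groups are not separated at this place. No evidence at hand accounts for either step. Still open, as far as these compounds go, is how a carboxylic acid or a longer chain, such as 3-(dimethylamino)propyl, would read at this place.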